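Swapping pyrrolidin-2-yl for piperidin-2-yl in compound 2

The source may hold more compounds than are shown below. What is called first, only, known or untested is meant among the compounds shown, and "the series" means these compounds.

Measured so far in a physicochemical assay for solubility, read by chemiluminescence, measured as kinetic solubility; a lower number here means a less soluble compound, a higher number a more soluble compound:
- compound 1 `O=C([C@@H]1CCCN1)N1CCC2(CCN(c3nccc(NCc4ccc(Cl)cc4Cl)n3)CC2)C1` gives 165 ug/mL
- compound 2 `Clc1ccc(CNc2ccnc(N3CCC4(CCN(CC5CCCN5)C4)CC3)n2)c(Cl)c1` gives 270 ug/mL

The values of these two compounds lie within the usual scatter of each other, so compound 2 stands level with compound 1 and neither can be ranked above the other.

Compound 3 `Clc1ccc(CNc2ccnc(N3CCC4(CCN(CC5CCCCN5)C4)CC3)n2)c(Cl)c1` has not yet been measured. It differs from compound 2 in one place: piperidin-2-yl in place of pyrrolidin-2-yl on a saturated chain carbon bound to an amine nitrogen in a ring. The change sits on a saturated chain carbon bound to an amine nitrogen in a ring, so it can also be read as (pyrrolidin-2-yl)methyl to (piperidin-2-yl)methyl.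

For the measured compounds named here, no measured step makes this exact swap. Going by the values given here, the only step that touches this part of the molecule is a 1.6-fold higher number from compound 1 to compound 2 (0.21 log units; within the scatter), and it stayed within the scatter. That is thin evidence, but it gives no reason to expect a step beyond the scatter in this assay, and no direction can be called. The expected step is a 1.1-fold lower number from compound 2 to compound 3 (0.05 log units; within the scatter) and it would also lie within the scatter. For compound 3 the estimated value is 240 ug/mL, with an expected range from 120 ug/mL to 450 ug/mL.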

Compound 3, solubility: 182 ug/mL
Compound 3: middle estimate off by 1.3-fold (0.12 log units), on the high side, within the range that was stated.
By their numbers in this assay, from the lowest: compounds 1, 3 and 2 (each within the scatter of the next).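

In this assay, pyrrolidin-2-yl gives way to piperidin-2-yl, a five-membered ring to a six-membered one, on a saturated chain carbon bound to an amine nitrogen in a ring, with a 1.5-fold lower number from compound 2 to compound 3 (0.17 log units; within the scatter) as the result. So this part of the molecule has now taken a change of ring size as well as the earlier change of carbonyl to methyl, and neither step gets beyond the scatter; the same holds when both changes are read together, with a 1.1-fold higher number from compound 1 to compound 3 (0.04 log units; within the scatter) as the step. No supporting measurement bears on these results.

Going by these compounds, what stays open is whether any group in this place can shift the number beyond the scatter, as all three compounds carry a saturated nitrogen ring here, and an open-chain amine such as dimethylaminomethyl or a carboxylic acid would test something quite different. On these data alone, it also stays open whether the ring nitrogen matters at all, which a cyclohexyl ring in place of piperidin-2-yl would help to show.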